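Thiophen-3-yl in place of 4-nitrophenyl

This account rests on a few compounds, and the source may have more. Where it says the series, first, only, none or still open, it means among the compounds named here.

In a functional assay on SW-620 cells (Homo sapiens) for antiproliferative activity, read by MTT assay, with a stated time of 24 h (on this read-out lower numbers stand for stronger inhibition and higher numbers for weaker inhibition), compound 1 (`COc1ccc(C(=O)/C=C/c2ccc(F)cc2)c2c1C=CC(C)(C)O2`) stands at > 10000 nM, which is a limit of the assay.

Among the compounds with values here, compound 2 (`COc1ccc(C(=O)/C=C/c2ccc([N+](=O)[O-])cc2)c2c1C=CC(C)(C)O2`) gives 3520 nM, the only actual number so far.

Compound 3 (`COc1ccc(C(=O)/C=C/c2ccsc2)c2c1C=CC(C)(C)O2`) carries thiophen-3-yl in place of 4-nitrophenyl on a double-bonded chain carbon bound to a double-bonded chain carbon.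

Within the data shown here, the one measured step touching this place is nitro in place of fluoro, an at least 2.8-fold lower number from compound 1 to compound 2 (0.45 log units; beyond the scatter). Compound 3 has no nitro, so on the evidence of an at least 2.8-fold lower number from compound 1 to compound 2 (0.45 log units; beyond the scatter) a step of similar size towards a higher number is expected in this assay. Among the measured compounds shown here, no measured compound carries thiophen-3-yl.

The expected step is a 2.3-fold higher number from compound 2 to compound 3 (0.36 log units; beyond the scatter).

For compound 3 the estimated value is 8000 nM, with an expected range of 3000 nM to 20000 nM.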

Compound 3, half-maximal inhibitory concentration: > 10000 nM
Compound 3 gave a limit, no number; the forecaster's own chance of this, stated with the estimate: 45%; middle value at least 1.2-fold (0.09 log units) away from the limit.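

In this assay, thiophen-3-yl in place of 4-nitrophenyl on a double-bonded chain carbon bound to a double-bonded chain carbon gives an at least 2.8-fold higher number from compound 2 to compound 3 (0.45 log units; beyond the scatter). Of the three groups at this place, only 4-nitrophenyl yields an actual number, and a five-membered aromatic ring with sulfur does not restore one. The step between compound 1 and compound 3 cannot be read, and little in the series can be ranked: the limit of > 10000 nM in this assay, at which 2 of the 3 values shown sit.

Going by these compounds, what an amine or a carboxylic acid in place of the nitro group would give stays open. On these data alone, whether any thiophene-bearing compound can give a number also stays open.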